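This account rests on a few compounds, and the source may have more. Where it says the series, first, only, none or still open, it means among the compounds named here.

Compound 1 `CC[C@H](C)[C@H](NC(=O)CN(c1nc(Cl)nc2[nH]cnc12)C1CC1)C(=O)O` gives 27.4% in a functional assay on the whole organism (Tail, strain ICR) with Mus musculus as the target, in the tail flick test, with a stated time of 90 min, at a dose of 25 umol/kg by the oral route; on this read-out higher numbers stand for a stronger effect at the one dose given and lower numbers for a weaker effect. Compound 3 `C[C@@H](O)[C@H](NC(=O)CN(c1nc(Cl)nc2[nH]cnc12)C1CC1)C(=O)O` gives 35.9% in this assay; the change between them is hydroxy in place of ethyl on a saturated chain carbon bound to two saturated chain carbons, and the step it made is a number 8.5 percentage points higher from compound 1 to compound 3 (within the scatter). Compound 2 `CC[C@H](C)[C@H](NC(=O)CN(c1ncnc2c1ncn2C1CCCCO1)C1CC1)C(=O)OCc1ccccc1`, built on another core, gives 22.6% in this assay; the difference between the two cores is not broken down here. Compound 4 `C[C@@H](O)[C@H](NC(=O)CN(c1ncnc2c1ncn2C1CCCCO1)C1CC1)C(=O)OCc1ccccc1` is not yet measured; it differs from compound 2 by hydroxy in place of ethyl on a saturated chain carbon bound to two saturated chain carbons, the same change at the same place as between compound 1 and compound 3. The expected step is a number 7.4 percentage points higher from compound 2 to compound 4 (within the scatter) in this assay, resting on the earlier step of a number 8.5 percentage points higher from compound 1 to compound 3 (within the scatter) on the other core, a single step that itself lies within the scatter. Compound 4 is estimated at 30%, with a range from 18% to 42%.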

Compound 4, a percentage reported as activity, at one dose (the size of the read-out at that dose, not a potency): 23.4%
For compound 4 the middle estimate is 6.6 percentage points above the measured one; the range from low to high includes it.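

The change gives a number 0.8 percentage points higher from compound 2 to compound 4 (within the scatter) in this assay, and set beside the earlier step it does not differ from it: the same change on two cores in this assay, a number 8.5 percentage points higher (within the scatter) from compound 1 to compound 3 and a number 0.8 percentage points higher (within the scatter) from compound 2 to compound 4, 7.7 percentage points apart, within the scatter of two such steps
Since both steps lie within the scatter, neither core shows a clear effect of hydroxy in place of ethyl, and the pair gives no sign that the outcome depends on the core. Two pairs do not establish that the change carries over as a real gain, nor do they exclude a core dependence smaller than the scatter.

Going by these compounds, what an amine, a carboxylic acid or a longer chain would do on that saturated chain carbon stays open on both cores. Also open, on these data alone, is how the change behaves on any core beyond these two.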